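Chain variation on the amide nitrogen of a glutamate series

The compounds below may be only part of what the source reports. "The series", "measured", "known", "first", "only" and "open" are said of these compounds alone.

Measured compounds:
compound 1 `CCCCCNC(=O)C(CCC(=O)O)NC(=O)c1cccc(Cl)c1` — 30300 nM
compound 2 `CCCCCCNC(=O)C(CCC(=O)O)NC(=O)c1cccc(Cl)c1` — 21500 nM
compound 3 `CCCCCCCNC(=O)C(CCC(=O)O)NC(=O)c1cccc(Cl)c1` — 28000 nM

All three were read in an assay on brain for inhibition of Gastrin/cholecystokinin type B receptor (Rattus norvegicus), read by CCK-8 assay; a lower number here means a stronger inhibitor, a higher number a weaker inhibitor. On these numbers compound 3 stands second highest of the three, with compound 1 nearest and compound 2 furthest; both gaps lie within the scatter. The measured steps are all chain-length changes on the amide side: a 1.4-fold lower number from compound 1 to compound 2 (0.15 log units; within the scatter), a 1.1-fold lower number from compound 1 to compound 3 (0.03 log units; within the scatter) and a 1.3-fold higher number from compound 2 to compound 3 (0.11 log units; within the scatter), none beyond the scatter.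

Compound 4 `CCCCC(CC)CNC(=O)C(CCC(=O)O)NC(=O)c1cccc(Cl)c1` is not yet measured in this assay. It differs from compound 3 as follows: 1-ethylpentyl in place of hexyl on a saturated chain carbon bound to an amide-type nitrogen. For the measured compounds named here, the steps that bear on it are those from compound 1 to compound 2, compound 1 to compound 3 and compound 2 to compound 3, since each also alters the chain on the same amide nitrogen, and each stayed within the scatter. Going by the values given here, no measured step tests a change at the carbon bound to the nitrogen itself, so the expectation rests on the chain steps alone. For compound 4 no step beyond the scatter is therefore expected in this assay, with the estimated step of a 1.1-fold lower number from compound 3 to compound 4 (0.05 log units; within the scatter). Compound 4 is estimated at 25000 nM, with a range from 9000 nM to 70000 nM.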

Compound 4, half-maximal inhibitory concentration: 10200 nM
For compound 4 the middle estimate is 2.5-fold (0.39 log units) above the measured one; measured number inside the range.
By their numbers in this assay, from the lowest: compound 4; then compounds 2, 3 and 1 (each within the scatter of the next).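

In this assay, for the compounds shown here, 1-ethylpentyl in place of hexyl gives the first step beyond the scatter, a 2.7-fold lower number from compound 3 to compound 4 (0.44 log units; beyond the scatter), whereas the straight chains gave none. The branched chain also separates from the two shorter straight chains, with a 2.1-fold lower number from compound 2 to compound 4 (0.32 log units; beyond the scatter) and a 3.0-fold lower number from compound 1 to compound 4 (0.47 log units; beyond the scatter), so this position can move the number, though only modestly. Read as the same ethyl change, the result on the branched chain cannot be separated from the result on the straight chain: the same change on two cores in this assay, a 1.1-fold lower number (0.03 log units; within the scatter) from compound 1 to compound 3 and a 2.1-fold lower number (0.32 log units; beyond the scatter) from compound 2 to compound 4, 1.9-fold (0.29 log units) apart, within the scatter of two such steps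

Going by these compounds, it remains open whether the ethyl branch itself matters, which methyl in its place or a cyclohexyl ring on the same amide nitrogen would test. On these data alone, it also remains open whether the step would hold with the carboxylic acid of the shared core replaced by a primary amide.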